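Prostacyclin synthase series: aryl ether variation at compound 3

The compounds below may be only part of what the source reports. "The series", "measured", "known", "first", "only" and "open" are said of these compounds alone.

Compound 1 `N#Cc1ccccc1C1OCC(C/C=C\CCC(=O)O)C(c2cccnc2)O1` — in an assay for inhibition of prostacyclin synthase (Homo sapiens), using microsomes (on this read-out lower numbers stand for stronger inhibition and higher numbers for weaker inhibition), reaches only the assay limit, > 100000 nM.
Compound 2 `O=C(O)CC/C=C\CC1COC(c2ccc([N+](=O)[O-])cc2)OC1c1cccnc1` — in this assay gives 13000 nM.
Compound 3 `CC(C)(Oc1ccc(F)cc1)C1OCC(C/C=C\CCC(=O)O)C(c2cccnc2)O1` — in this assay gives 2000 nM.

Compound 3 holds the lowest of the two numbers measured; its nearest neighbour is compound 2, whose value is higher by a margin beyond the scatter, and compound 1 is recorded only as a limit (the limit of > 100000 nM in this assay, at which 1 of the 3 values shown sits).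

Compound 4 `CC(C)(Oc1ccccc1O)C1OCC(C/C=C\CCC(=O)O)C(c2cccnc2)O1` is not yet measured. It differs from compound 3 by 2-hydroxyphenyl in place of 4-fluorophenyl on an oxygen on a saturated carbon. Among the measured compounds shown here, the single measured step, an at least 7.6-fold lower number from compound 1 to compound 2 (0.88 log units; beyond the scatter), concerns a different part of the molecule, the aryl group on a saturated ring carbon, not the aryl ether; it does not bear directly on the change from compound 3 to compound 4. For the measured compounds named here, no measured pair varies the aryl ether itself, so the expected effect in this assay rests on no precedent and is estimated as no shift beyond the scatter, a 1.3-fold higher number from compound 3 to compound 4 (0.10 log units; within the scatter).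

Compound 4 is therefore estimated at 2500 nM, between 600 nM and 10000 nM.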

Compound 4, half-maximal inhibitory concentration: > 100000 nM
Compound 4: no number, only a limit (the forecaster's own chance of this, stated with the estimate: 2%); middle value at least 40-fold (1.60 log units) from the limit.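

In this assay, among the compounds shown here, the aryl ether is not a silent place: 2-hydroxyphenyl in place of 4-fluorophenyl on an oxygen on a saturated carbon gives an at least 50-fold higher number from compound 3 to compound 4 (1.69 log units; beyond the scatter), the only measured step at this place. This one exchange, with the rest of the molecule unchanged, is enough to take compound 4 out of the measurable range. Compound 4 is recorded only as a limit, which it shares with compound 1: the limit of > 100000 nM in this assay, at which 2 of the 4 values shown sit.

The change removes the fluorine and adds the hydroxyl in a single step, and the compounds shown do not separate the two contributions. On these data alone, how an unsubstituted phenyl, or a methoxy group in place of the hydroxyl, would read in this assay stays open.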